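Fluoro Added to the Thiomorpholine Thiosemicarbazone

The compounds below may be only part of what the source reports. "The series", "measured", "known", "first", "only" and "open" are said of these compounds alone.

In a functional assay on MCF7 cells (Homo sapiens) for cytotoxicity, read by MTT assay, with a stated time of 72 h, tested at 30 uM (on this read-out higher numbers stand for more inhibition of growth at the one concentration tested and lower numbers for less inhibition of growth), compound 2 `N/C(=N\NC(=S)N1CCSCC1)c1ccccn1` gives 72.6%, the highest of the two numbers shown. Its nearest neighbour, compound 1 `N/C(=N\NC(=S)N1CCCC1)c1ccc(F)cn1`, gives 60.6% in this assay, a gap beyond the usual scatter. Compound 3 `N/C(=N\NC(=S)N1CCSCC1)c1ccc(F)cn1` differs from compound 2 by fluoro in place of hydrogen on an aromatic carbon, a fluoro in place of hydrogen on an aromatic carbon. Within the data shown here, no measured pair shows this single change, so its direction is not settled by the data. The step of a number 4.6 percentage points lower from compound 2 to compound 3 (within the scatter) is expected to remain within the scatter. Compound 3 is therefore estimated at 68%, between 50% and 82%.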

Compound 3, percent growth inhibition at one concentration: 58.8%
The estimate for compound 3 lay 9.2 percentage points above the measured number; the measured number falls inside the stated range.
By their numbers in this assay, from the lowest: compounds 3 and 1 (each within the scatter of the next); then compound 2.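

In this assay, among these compounds, the single change of fluoro in place of hydrogen on an aromatic carbon, two atoms from the ring nitrogen, now has a measured direction: a number 13.8 percentage points lower from compound 2 to compound 3 (beyond the scatter). With fluoro in place, thiomorpholin-4-yl in place of pyrrolidin-1-yl on a thiocarbonyl carbon gives a number 1.8 percentage points lower from compound 1 to compound 3 (within the scatter), so this pair does not separate the two groups. Nothing available explains the effect of the fluoro. The compounds shown leave open whether chloro, methoxy or an amine on this carbon would give a similar step, and whether the fluoro step would hold with pyrrolidin-1-yl on the thiocarbonyl carbon.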